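The compounds below may be only part of what the source reports. "The series", "measured", "known", "first", "only" and "open" are said of these compounds alone.

Measured compounds:
- compound 1, `COC1=C(OC)[C@H](O)[C@H](C/C=C(\C)CC/C=C(\C)C[C@H](O)/C=C(\C)CO)[C@@H](C)C1=O`; in a functional assay on PC-3 cells (Homo sapiens) for inhibition, read by sulforhodamine B assay, with a stated time of 48 h (on this read-out higher numbers stand for weaker inhibition of growth and lower numbers for stronger inhibition of growth), compound 1 gives a limit of > 30000 nM
- compound 2, `COC1=C(OC)[C@H](O)[C@H](C/C=C(\C)CC/C=C(\C)CC/C=C(\C)CO)[C@@H](C)C1=O`; in this assay compound 2 gives a limit of > 30000 nM

Compound 2 stands at the limit of this assay, and no number was obtained for it. Going by the values given here, the only measured step, a step that the two limits leave unreadable from compound 1 to compound 2, cannot be read in size or direction, since both compounds sit at the limit of > 30000 nM in this assay, at which 2 of the 2 values shown sit. Compound 3, `COC1=C(OC)[C@H](O)[C@H](C/C=C(\C)CC/C=C(\C)CCCC(C)CO)[C@@H](C)C1=O`, is not yet measured. It differs from compound 2 by 2-(hydroxymethyl)propyl in place of 2-(hydroxymethyl)prop-1-en-1-yl on a saturated chain carbon, two bonds along the chain from a double-bonded chain carbon. Among the compounds with values here, no measured step bears readably on this change, because the values shown for compound 2 and compound 1 are limits (the limit of > 30000 nM in this assay, at which 2 of the 2 values shown sit). Compound 3 is therefore expected to remain at the limit, the expected step being a step that the limit leaves unreadable from compound 2 to compound 3. The estimate for compound 3 in this assay is 60000 nM, with a range from 20000 nM to 300000 nM.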

Compound 3, concentration for 50% growth inhibition: > 30000 nM
Compound 3 was reported as a limit; the forecaster's own chance of this, stated with the estimate: 85%; the middle value is on the limit's open side.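

Going by these compounds alone, no step among compound 1, compound 2 and compound 3 can be read in size or direction, since each is reported only as a limit and not as a number: the limit of > 30000 nM in this assay, at which 3 of the 3 values shown sit. The compounds shown leave open whether any of these chain changes alters inhibition of growth.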